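This account rests on a few compounds, and the source may have more. Where it says the series, first, only, none or still open, it means among the compounds named here.

Series notes. Compound 1 `Cc1cc(O)cc(-c2nn(CC#N)cc2-c2ccnc(-c3ccc(Oc4ccccc4)cc3)c2)c1` and compound 2 `COc1cc(C)cc(-c2nn(CC#N)cc2-c2ccnc(-c3ccc(N(C)C)cc3)c2)c1` share the same core. In a functional assay on COLO 205 cells (Homo sapiens) for cytotoxicity, read by sulforhodamine B assay, with a stated time of 48 h, tested at 1 uM (a lower number here means a stronger effect, a higher number a weaker effect of the compound at the concentration tested), compound 1 gives -94%, and in this assay compound 2 gives -74%, the higher of the two numbers, with the number of compound 1 lying lower, beyond the scatter. Compound 3 `Cc1cc(O)cc(-c2nn(CC#N)cc2-c2ccnc(-c3ccc(N(C)C)cc3)c2)c1` has not been measured. Relative to compound 2 the change is hydrogen in place of methyl on an oxygen on an aromatic ring. For the measured compounds named here, no measured pair isolates this change, so no step size is known from the data. A step of a number 8 percentage points lower from compound 2 to compound 3 (within the scatter) in this assay is expected, within the scatter. Compound 3 is expected to give -82%, between -100% and -60%.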

Compound 3, a percentage reported as activity, at one concentration (the size of the read-out at that concentration, not a potency): -59%
The estimate for compound 3 lay 23 percentage points below the measured number, outside the stated range (above it).
By their numbers in this assay, from the lowest: compound 1; then compound 2; then compound 3.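

In this assay, for the compounds shown here, methoxy to hydroxy on the aromatic ring gives a number 15 percentage points higher from compound 2 to compound 3 (beyond the scatter), so with dimethylamino held, the methyl on this oxygen counts for more than the earlier compounds could show. With hydroxy held, dimethylamino in place of phenoxy on an aromatic carbon gives a number 35 percentage points higher from compound 1 to compound 3 (beyond the scatter), so the phenoxy site also moves the read-out. Nothing available gives a reason for either step. Going by these compounds, whether the methoxy to hydroxy step keeps its direction with phenoxy present remains open, as does how a longer chain such as ethoxy, or an amine, would read at this oxygen-bearing position.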